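Thiophene-for-phenyl swap on a nucleoside series

The source may hold more compounds than are shown below. What is called first, only, known or untested is meant among the compounds shown, and "the series" means these compounds.

Measured so far:
compound 1, `COc1ncnc2c1c(-c1cccs1)cn2[C@@H]1O[C@H](CO)[C@@H](O)[C@H]1O`, 80 nM
compound 2, `COc1ncnc2c1c(-c1ccccc1)cn2[C@@H]1O[C@H](CO)[C@@H](O)[C@H]1O`, > 20000 nM
compound 3, `CNc1ncnc2c1c(-c1ccccc1)cn2[C@@H]1O[C@H](CO)[C@@H](O)[C@H]1O`, > 20000 nM

In a functional assay on HCT-116 cells (Homo sapiens), read by MTT assay, with a stated time of 72 h (on this read-out higher numbers stand for weaker inhibition and lower numbers for stronger inhibition), compound 1 gives 80 nM. For compound 2 the value > 20000 nM is a limit of the assay, not a number. For compound 3 the value > 20000 nM is likewise a limit. Compound 2 and compound 1 differ by thiophen-2-yl in place of phenyl on an aromatic carbon, and this gives an at least 250-fold lower number from compound 2 to compound 1 (2.39 log units; beyond the scatter). The cores of compound 2 and compound 3 differ by methylamino in place of methoxy on an aromatic carbon, which gives a step that the two limits leave unreadable from compound 2 to compound 3; the limit of > 20000 nM in this assay, at which 2 of the 3 values shown sit, leaves that step unreadable.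

Compound 4, `CNc1ncnc2c1c(-c1cccs1)cn2[C@@H]1O[C@H](CO)[C@@H](O)[C@H]1O`, is not yet measured. It differs from compound 3 by thiophen-2-yl in place of phenyl on an aromatic carbon, the same change as from compound 2 to compound 1, at the same place. Resting on the large step of an at least 250-fold lower number from compound 2 to compound 1 (2.39 log units; beyond the scatter), the step from compound 3 to compound 4 is expected to be an at least 66-fold lower number from compound 3 to compound 4 (1.82 log units; beyond the scatter), though the limit of compound 3 leaves its true size open. Compound 4 is estimated at 300 nM in this assay, between 50 nM and 5000 nM.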

Compound 4, half-maximal inhibitory concentration: > 20000 nM
Compound 4 gave a limit, no number; the forecaster's own chance of this, stated with the estimate: 15%; at least 66-fold (1.82 log units) between middle value and limit.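

In this assay, compound 4 gives > 20000 nM, which is a limit and not a number. With thiophen-2-yl held fixed, methylamino in place of methoxy gives an at least 250-fold higher number from compound 1 to compound 4 (2.39 log units; beyond the scatter), so the thiophene-for-phenyl gain seen on the methoxy core does not carry over to the methylamino core as a measurable potency. The steps between compound 2 and compound 3 and between compound 3 and compound 4 cannot be read, and any smaller effect of the swap on the methylamino core stays hidden: the limit of > 20000 nM in this assay, at which 3 of the 4 values shown sit.

Still open, from the compounds shown here alone, is whether potency with thiophen-2-yl depends on methoxy specifically or would survive with ethoxy or a dimethylamino group there. Going by these compounds, whether another five-membered ring, such as furan-2-yl, would match thiophen-2-yl is also open.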